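Adding a Cyano Group: Expected Effect on Cell Tolerance

A few compounds are considered here, and "the series" means these few. Any claim that something is new, unique, unknown or untested is made for them only; others in the source may bear on it.

Compound 1 `COc1ccccc1Oc1nc(Nc2ccc(C#N)cc2)nc2ccccc12` was tested in an ADME assay on MT4 cells (Homo sapiens) for cytotoxicity, read by MTT assay, with a stated time of 4 days (a higher number here means that more compound is tolerated, a lower number that less compound is tolerated), where compound 1 gives 150000 nM, the highest of the two numbers recorded. Compound 2 `CCOc1cc(C#N)cc(OCC)c1Oc1nc(Nc2ccc(C#N)cc2)nc2ccccc12` gives 108000 nM in this assay, a value within the scatter of that of compound 1. Compound 3 `COc1cc(C#N)ccc1Oc1nc(Nc2ccc(C#N)cc2)nc2ccccc12` has not yet been measured. It differs from compound 1 by cyano in place of hydrogen on an aromatic carbon, meta to a methoxy group. Going by the values given here, no measured step of this kind is available, so the step of a 1.3-fold lower number from compound 1 to compound 3 (0.10 log units; within the scatter) is expected to stay within the scatter. Compound 3 is estimated to give 120000 nM, within a range from 60000 nM to 240000 nM.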

Compound 3, half-maximal cytotoxic concentration: >= 140000 nM
Compound 3 was reported as a limit; the forecaster's own chance of this, stated with the estimate: 10%; at least 1.1-fold (0.06 log units) between middle value and limit.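

In this assay, going by these compounds alone, compound 3 is reported only as a limit, >= 140000 nM and so no step between compound 1 and compound 3 can be read. From the compounds shown here alone, whether cyano in place of hydrogen at this position changes how much compound the cells tolerate stays open.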